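The source may report more compounds than this note shows. Statements on the series, on what has been measured and on what is new or still open speak of the compounds shown alone.

Measured compounds and their values in a functional assay on HEL cells (Homo sapiens) for cytotoxicity; a lower number here means that less compound is tolerated, a higher number that more compound is tolerated:

compound 1, `CCC(C)C1NC(=O)N(C2CCCC2)C1=O` — > 100 ug/mL
compound 2, `CC(C)C1NC(=O)N(C2CCCC2)C1=O` — > 100 ug/mL
compound 3, `CCC(C)C1NC(=O)N(Cc2ccccc2)C1=O` — 100 ug/mL

Compound 2 sits at > 100 ug/mL in this assay, which is a limit of the assay rather than a number. Compound 1 likewise gives > 100 ug/mL, again a limit. Compound 3 gives 100 ug/mL. Within the data shown here, the only step between measured compounds that differ in one place, a step that the two limits leave unreadable from compound 1 to compound 2, cannot be read because both of its ends are limits; the picture is summed up by the limit of > 100 ug/mL in this assay, at which 2 of the 3 values shown sit, at which two of the three values shown sit.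

Compound 4, `O=C1NC(c2ccccc2)C(=O)N1C1CCCC1`, is not yet measured. It differs from compound 2 in one place, (phenyl in place of isopropyl on a saturated ring carbon). Among the measured compounds shown here, no measured step involves a phenyl entering in place of isopropyl at this position, so no step size bears directly on it. For the measured compounds named here, what the data do show is that no compound measured so far is tolerated only at a low concentration, and compound 3 gives 100 ug/mL. Compound 4 is therefore expected to tolerate a similarly high concentration, with an estimate of 100 ug/mL and a range from 50 ug/mL to 200 ug/mL. The expected step of a number no higher from compound 2 to compound 4 (the limit leaves the size open) is accordingly estimated as none beyond the scatter.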

Compound 4, minimum cytotoxic concentration: >= 20 ug/mL
Compound 4: no number, only a limit; the forecaster's own chance of this, stated with the estimate: 50%; the middle value lies beyond the limit too.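

In this assay compound 4 gives >= 20 ug/mL, which is a limit of the assay. Neither the step from compound 2 to compound 4 nor the step from compound 1 to compound 4 can be read, as both ends of each are limits. The compounds shown leave open whether phenyl in place of isopropyl on a saturated ring carbon changes the value in this assay at all.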